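Swapping the nitrophenyl group for a nitropiperazine

A few compounds are considered here, and "the series" means these few. Any claim that something is new, unique, unknown or untested is made for them only; others in the source may bear on it.

Compound 1 `O=C(O)c1ccc(C(=O)/C(=C\c2ccc(O)c([N+](=O)[O-])c2)SCc2ccc(Br)cc2)cc1` gives 50000 nM
Compound 2 `O=C(O)c1ccc(C(=O)/C(=C\c2ccc(Cl)c([N+](=O)[O-])c2)SCc2ccc(Br)cc2)cc1` gives 500 nM
Compound 3 `O=C(O)c1ccc(C(=O)/C(=C\c2ccc(Cl)c([N+](=O)[O-])c2)SCc2ccccc2F)cc1` gives 1000 nM

All three values come from a functional assay on DU-145 cells (Homo sapiens) for inhibition, read by trypan blue exclusion, with a stated time of 96 h (a lower number here means a stronger inhibitor of growth, a higher number a weaker inhibitor of growth), and a lower number means stronger growth inhibition. Compound 2 sits at the low end of these numbers, level with compound 3 within the scatter and well clear of compound 1.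

Compound 4 `CN1CCN(/C=C(/SCc2ccc(Br)cc2)C(=O)c2ccc(C(=O)O)cc2)CC1[N+](=O)[O-]` has not been measured yet. It differs from compound 2 on a double-bonded chain carbon bound to a double-bonded chain carbon, where the change is 4-methyl-3-nitropiperazin-1-yl in place of 4-chloro-3-nitrophenyl on a double-bonded chain carbon bound to a double-bonded chain carbon and an aromatic ring gives way to a non-aromatic one.

Among the compounds with values here, no measured step makes this whole swap, so the evidence is indirect. The closest is a 100-fold lower number from compound 1 to compound 2 (2.00 log units; beyond the scatter) for chloro in place of hydroxy on an aromatic carbon, a large step from a single change within the group now leaving. The step of a 2.0-fold higher number from compound 2 to compound 3 (0.30 log units; within the scatter) stayed within the scatter, but that change sits elsewhere, on a saturated chain carbon bound to a sulfur.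

A higher number is therefore expected, and the estimated change is a 10-fold higher number from compound 2 to compound 4 (1.00 log units; beyond the scatter) with much uncertainty in its size. The estimate for compound 4 is 5000 nM in an expected range of 700 nM to 40000 nM in this assay.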

Compound 4, concentration for 50% growth inhibition: 10000 nM
Compound 4: the middle estimate sits 2.0-fold (0.30 log units) below what was measured, and the stated range covers the measured number.
By their numbers in this assay, from the lowest: compounds 2 and 3 (each within the scatter of the next); then compound 4; then compound 1.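

In this assay, the aromatic ring at this place turns out to matter, since 4-methyl-3-nitropiperazin-1-yl in place of 4-chloro-3-nitrophenyl gives a 20-fold higher number from compound 2 to compound 4 (1.30 log units; beyond the scatter) and so loses much of the growth inhibition. A non-aromatic ring is still not the poorest group seen on this double-bonded chain carbon, as 4-methyl-3-nitropiperazin-1-yl in place of 4-hydroxy-3-nitrophenyl gives a 5.0-fold lower number from compound 1 to compound 4 (0.70 log units; beyond the scatter), which places it between the two aromatic groups. Nothing measured here explains why the ring swap moves the numbers this way.

As far as these compounds go, it remains open how a morpholine ring, or a piperazine ring without the nitro group, would compare at this place. Also open, from the compounds shown here alone, is whether the step from the chloro compound keeps its size when the 2-fluorophenyl group of compound 3 replaces 4-bromophenyl.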